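The source may report more compounds than this note shows. Statements on the series, on what has been measured and on what is new or still open speak of the compounds shown alone.

Three compounds built on a shared core were tested in a functional assay on KYSE-410 cells (Homo sapiens) for antiproliferative activity, read by MTT assay, with a stated time of 72 h; a lower number here means a stronger inhibitor, a higher number a weaker inhibitor. Compound 1 `O=C(Nc1ccc(F)cc1)c1cc(=O)[nH]c2cc(Br)ccc12` reaches only the limit of this assay, giving > 20000 nM. Compound 2 `O=C(Nc1cc(F)cc(F)c1)c1cc(=O)[nH]c2cc(F)ccc12` likewise returns only the limit, > 20000 nM. Compound 3 `O=C(Nc1cccc(F)c1)c1cc(=O)[nH]c2cc(-c3ccccc3)ccc12` also stops at the limit, with > 20000 nM. Among the measured compounds shown here, compound 3 thus stands where every measured compound stands, at the limit of > 20000 nM in this assay, at which 3 of the 3 values shown sit, and no measured step separates any two of them; the numbers show only that none of the three gave a value inside the measurable range.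

Compound 4 `C#Cc1ccc2c(C(=O)Nc3cccc(F)c3)cc(=O)[nH]c2c1` differs from compound 3 in one place: ethynyl in place of phenyl on an aromatic carbon. For the measured compounds named here, with every measured compound at the limit, no measured step tells how such a change moves this assay. The step expected in this assay from the change is small or none beyond the scatter, and a reading at the limit again appears the likelier outcome. Compound 4 is estimated at 20000 nM in this assay, within 5000 nM to 40000 nM. The step this estimate means, a number no higher from compound 3 to compound 4 (the limit leaves the size open), is expected to stay within the scatter, with the real uncertainty being whether a number rather than a limit is reported at all.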

Compound 4, half-maximal inhibitory concentration: 9700 nM
Beside the measured number, compound 4's estimate is 2.1-fold (0.31 log units) above it, and the stated range covers the measured number.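

In this assay, ethynyl in place of phenyl on this aromatic carbon, meta to a fused ring and para to a fused ring, gives an at least 2.0-fold lower number from compound 3 to compound 4 (0.31 log units; beyond the scatter), a step beyond the scatter and the first that can be read in the series. The earlier compounds shown here showed only readings at the limit, whereas compound 4 shows that a change at this one position can bring the shared core into the measurable range, here with ethynyl, which has no ring, where phenyl stood. The true size of the step remains open because compound 3 gives only a limit, and the step is therefore a lower bound: the limit of > 20000 nM in this assay, at which 3 of the 4 values shown sit.

This single pair cannot tell whether the gain follows from the loss of the aromatic ring or from the triple bond, and it sets no trend for the position. On these data alone, how an amine, a methoxy group or a longer alkyne chain on this carbon would read in this assay stays open, as does whether the fluorine pattern on the anilide ring matters once a number can be read.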